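Chloro for methyl on two cores: cytotoxicity limits

This account rests on a few compounds, and the source may have more. Where it says the series, first, only, none or still open, it means among the compounds named here.

Compound 1, `C=CC1=C(C(=O)NCc2ccc(C)cc2)C(c2ccc(F)cc2)OC1`, in a functional assay on A549 cells (Homo sapiens) for cytotoxicity, read by MTT assay, with a stated time of 24 h (on this read-out higher numbers stand for weaker inhibition and lower numbers for stronger inhibition), gives > 100000 nM, which is a limit of the assay rather than a number.
Compound 2, `C=CC1=C(C(=O)NCc2ccc(Cl)cc2)C(c2ccc(F)cc2)OC1`, in this assay gives > 100000 nM, again a limit.
Compound 3, `C=CC1=C(C(=O)NCc2ccc(C)cc2)C(c2ccc(OC)c(OC)c2)OC1`, in this assay gives > 100000 nM, also a limit.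

Compound 1 and compound 2 differ in one place, (chloro in place of methyl on an aromatic carbon). The step between them is a step that the two limits leave unreadable from compound 1 to compound 2; its size cannot be read because the limit of > 100000 nM in this assay, at which 3 of the 3 values shown sit, holds both ends of it. Compound 3 carries the same change on the way to the unmeasured compound 4, `C=CC1=C(C(=O)NCc2ccc(Cl)cc2)C(c2ccc(OC)c(OC)c2)OC1`: the difference is chloro in place of methyl on an aromatic carbon, and the surroundings of the place match those between compound 1 and compound 2, so it is the same change. How the core of compound 3 differs from the core of compound 1 is not broken down here. With every measured value sitting at the limit, the step expected from compound 3 to compound 4 is a step that the limit leaves unreadable from compound 3 to compound 4, resting only on that shared limit. Compound 4 is expected at 150000 nM, between 50000 nM and 500000 nM, and most probably reported as a limit.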

Compound 4, half-maximal inhibitory concentration: > 100000 nM
Compound 4 was reported as a limit; the forecaster's own chance of this, stated with the estimate: 85%; the middle value is on the limit's open side.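

Compound 3 and compound 4 both sit at a limit rather than a number, so the size of the step between them, chloro in place of methyl, cannot be read: the limit of > 100000 nM in this assay, at which 4 of the 4 values shown sit.

The compounds shown leave open whether this change has any effect at all, and what actual value any of the four would give in this assay.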